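Lengthening the hydroxycarbamoyl chain on the shared core

The source may report more compounds than this note shows. Statements on the series, on what has been measured and on what is new or still open speak of the compounds shown alone.

- Compound 1 `O=C(O)c1ccc2c(c1)no[n+]2[O-]` gives "not determined" (no result reported) 
- Compound 2 `O=C(CCCOC(=O)c1ccc2c(c1)no[n+]2[O-])NO` gives 2090 nM 
- Compound 3 `O=C(CCCCCCOC(=O)c1ccc2c(c1)no[n+]2[O-])NO` gives 1260 nM 

Among the measured compounds shown here, in a functional assay on HEL cells (Homo sapiens) for inhibition, read by MTT assay, with a stated time of 48 h (on this read-out higher numbers stand for weaker inhibition and lower numbers for stronger inhibition), compound 2 gives 2090 nM as one of only two numbers, and it stands level with compound 3 within the usual scatter. Compound 4 `O=C(CCCCCCCOC(=O)c1ccc2c(c1)no[n+]2[O-])NO` is not yet measured, and its change from compound 2 is 4-(hydroxycarbamoyl)butyl in place of hydroxycarbamoyl on a saturated chain carbon, three bonds along the chain from an oxygen next to a carbonyl group on a saturated chain carbon. For the measured compounds named here, one measured step bears on this: a 1.7-fold lower number from compound 2 to compound 3 (0.22 log units; within the scatter) puts 3-(hydroxycarbamoyl)propyl at that same place. A similar small step is therefore expected, a 1.6-fold lower number from compound 2 to compound 4 (0.21 log units; within the scatter) in the same direction, and no clear move beyond the scatter is expected. For compound 4 the estimate is 1300 nM with an expected range of 600 nM to 2800 nM in this assay.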

Compound 4, half-maximal inhibitory concentration: 1500 nM
Compound 4: middle estimate off by 1.2-fold (0.06 log units), on the low side; measured number inside the range.
By their numbers in this assay, from the lowest: compounds 3, 4 and 2 (each within the scatter of the next).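

In this assay, placing 4-(hydroxycarbamoyl)butyl at this position gives a 1.4-fold lower number from compound 2 to compound 4 (0.14 log units; within the scatter) and so does not clearly change the result. Placing (hydroxycarbamoyl)methyl on the hydroxycarbamoyl position of the shorter chain gives a 1.2-fold higher number from compound 3 to compound 4 (0.08 log units; within the scatter) as a second small step, so the three chain lengths cannot be told apart and no trend with length appears. Nothing available explains this flat response.

Still open, on these data alone, is whether a longer chain would move the number beyond the scatter. Also open, as far as these compounds go, is what a carboxylic acid or an amine would do in place of the hydroxycarbamoyl end of the chain.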